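Working notes: hydrogen for fluoro, compound 3 to compound 4

The source may hold more compounds than are shown below. What is called first, only, known or untested is meant among the compounds shown, and "the series" means these compounds.

The series shares one core. Compound 1 `Fc1ccc(-c2nn3c(NC4CCCC4)cccc3c2-c2ccc3[nH]ccc3c2)cc1` gives 20000 nM in an ADME assay on Vero cells (Chlorocebus sabaeus) for cytotoxicity; a lower number here means that less compound is tolerated, a higher number that more compound is tolerated. Compound 2 `Fc1ccc(-c2nn3c(NC4CCCC4)cccc3c2-c2cc(NC3CCCC3)ncn2)cc1` reaches only a limit of this assay, > 40000 nM, which is the limit of > 40000 nM in this assay, at which 1 of the 3 values shown sits. Compound 3 `Fc1ccc(-c2nn3c(NC4CCCC4)cccc3c2-c2ccc(F)nc2)cc1` has no number in this assay; its entry reads "not determined" (no result reported), so compound 3 stands nowhere on the numbers shown. Compound 4 `Fc1ccc(-c2nn3c(NC4CCCC4)cccc3c2-c2cccnc2)cc1` differs from compound 3 by hydrogen in place of fluoro on an aromatic carbon. Within the data shown here, no measured step in this assay covers such a change, so no step beyond the scatter is expected in either direction for compound 4. Compound 4 is therefore estimated at 25000 nM, within 8000 nM to 40000 nM, near the values of compound 1 and compound 2.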

Compound 4, half-maximal cytotoxic concentration: > 40000 nM
Compound 4 was reported as a limit (the forecaster's own chance of this, stated with the estimate: 40%); middle value at least 1.6-fold (0.20 log units) away from the limit.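

In this assay compound 4 is a limit and not a number, the second reading at that limit in the series: the limit of > 40000 nM in this assay, at which 2 of the 4 values shown sit.

At this position, pyridin-3-yl in place of 1H-indol-5-yl gives an at least 2.0-fold higher number from compound 1 to compound 4 (0.30 log units; that floor lies within the scatter), so the change shows no step beyond the scatter. Compound 3 has no number, so the step from 6-fluoropyridin-3-yl to pyridin-3-yl cannot be read.

The compounds shown leave open whether fluoro on this aromatic carbon changes the reading at all. They also leave open how an amine or a methoxy group in that place would read in this assay.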